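A few compounds are considered here, and "the series" means these few. Any claim that something is new, unique, unknown or untested is made for them only; others in the source may bear on it.

Among the compounds with values here, compound 3 `CCCc1ccc(C(=O)Nc2cccc(NC(=O)COc3ccc4c(=O)ccoc4c3)c2)cc1` is the only compound here with a number: in an assay on isolated protein for inhibition of Rho-associated protein kinase 1 (Homo sapiens), read by scintillation counting, radiometric assay and 33P incorporation, with a stated time of 40 min, in the presence of a further agent that is not named here (on this read-out lower numbers stand for stronger inhibition and higher numbers for weaker inhibition), compound 3 gives 143 nM. Compound 1 `COc1cccc(OCC(=O)Nc2cccc(NC(=O)c3ccc(N(C)C)cc3)c2)c1` reaches only a limit of the assay, giving > 10000 nM in this assay. Compound 2 `CN(C)c1ccc(C(=O)Nc2cccc(NC(=O)COc3ccc4occc(=O)c4c3)c2)cc1` also stops at a limit, giving > 10000 nM. Within the data shown here, the single measured step, a step that the two limits leave unreadable from compound 1 to compound 2, cannot be read because of the limit of > 10000 nM in this assay, at which 2 of the 3 values shown sit. Compound 4 `COC(=O)c1ccc(C(=O)Nc2cccc(NC(=O)COc3ccc4c(=O)ccoc4c3)c2)cc1` differs from compound 3 by methoxycarbonyl in place of propyl on an aromatic carbon. No measured step touches this position, so the shown data give no direction for the change. A small step is expected, a 2.8-fold higher number from compound 3 to compound 4 (0.45 log units; beyond the scatter), near the edge of the usual scatter. Compound 4 is estimated at 400 nM, with a range from 100 nM to 3000 nM.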

Compound 4, half-maximal inhibitory concentration: 72 nM
Compound 4: the middle estimate sits 5.6-fold (0.74 log units) above what was measured, outside the stated range (below it).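

Replacing propyl with methoxycarbonyl gives a 2.0-fold lower number from compound 3 to compound 4 (0.30 log units; within the scatter), so in this assay the two groups cannot be told apart at this position. The position on the aromatic ring therefore accepts a group with 2 hydrogen-bond acceptors in place of one with 0, without a change beyond the scatter. Nothing measured here gives a reason for this result. From the compounds shown here alone, how a carboxylic acid, an amine or a longer carbon chain would read at this position remains open, as does whether the same swap would behave alike on a different core.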